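The source may hold more compounds than are shown below. What is called first, only, known or untested is meant among the compounds shown, and "the series" means these compounds.

In a functional assay on HT-29 cells (Homo sapiens) for cytotoxicity, read by sulforhodamine B assay (a lower number here means that less compound is tolerated, a higher number that more compound is tolerated), two compounds on a shared core have been measured. Compound 1 `COc1ccc(/C=N\NC(=S)NC(C)(C)CCC[C@](C)(O)[C@@H]2CC=C(C)CC2)cc1` gives > 100000 nM, which is a limit of the assay and not a number. Compound 2 `CC1=CC[C@@H]([C@@](C)(O)CCCC(C)(C)NC(=S)N/N=C\c2ccccc2[N+](=O)[O-])CC1` gives 44400 nM, the only true number shown.

Among the compounds with values here, the single measured step, with 2-nitrophenyl in place of 4-methoxyphenyl, is an at least 2.2-fold lower number from compound 1 to compound 2 (0.35 log units; beyond the scatter), which lies beyond the scatter. It rests on (the limit of > 100000 nM in this assay, at which 1 of the 2 values shown sits).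

Compound 3 `CC1=CC[C@@H]([C@@](C)(O)CCCC(C)(C)NC(=S)N/N=C\c2ccc([N+](=O)[O-])cc2)CC1` differs from compound 2 as follows: 4-nitrophenyl in place of 2-nitrophenyl on a carbon with a double bond to nitrogen. In words, it has 4-nitrophenyl in place of 2-nitrophenyl on a carbon with a double bond to nitrogen. The atoms stay the same and only their joining changes. Within the data shown here, the measured step of an at least 2.2-fold lower number from compound 1 to compound 2 (0.35 log units; beyond the scatter) exchanged one group for a different group, so it bears on this change only loosely, and no measurement yet compares the two nitrophenyl groups directly.

The expected change is a 1.0-fold higher number from compound 2 to compound 3 (0.01 log units; within the scatter), with no shift beyond the scatter in either direction. For compound 3 the estimated value is 45000 nM, with an expected range from 18000 nM to 100000 nM.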

Compound 3, concentration lethal to 50% of the cells: > 100000 nM
Compound 3 ended at the assay's limit (the forecaster's own chance of this, stated with the estimate: 15%); at least 2.2-fold (0.34 log units) between middle value and limit.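

Shifting the nitro group changes the reading even though the atoms stay the same: in this assay, 4-nitrophenyl in place of 2-nitrophenyl on a carbon with a double bond to nitrogen gives an at least 2.2-fold higher number from compound 2 to compound 3 (0.35 log units; beyond the scatter). The nitro group alone therefore does not set the reading at this place, since of the two nitrophenyl compounds only compound 2 gives a true number, and the lower number seen earlier goes with 2-nitrophenyl among the groups shown here. Compound 3 gives a limit of the assay and not a number, so the step to it shows only a minimum size, and the step between compound 1 and compound 3 cannot be read: the limit of > 100000 nM in this assay, at which 2 of the 3 values shown sit.

Going by these compounds, how far compound 1 and compound 3 truly lie from compound 2 remains open, as does whether either of them differs from the other. On these data alone, it is also open whether a nitrile, an amine or a carboxylic acid in place of the nitro group on the aromatic ring would give a true number in this assay, or would leave the reading at the limit.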